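This account rests on a few compounds, and the source may have more. Where it says the series, first, only, none or still open, it means among the compounds named here.

Measured so far in an assay on isolated protein for inhibition of RAC-beta serine/threonine-protein kinase (Homo sapiens), read by mobility shift assay, tested at 30 uM; a higher number here means more inhibition at the concentration tested (going by the name of the read-out), a lower number less inhibition:
compound 1, `COCCNc1nc(C)cc2c1c(N)nn2C`: -3%
compound 2, `COCCNc1nc(-c2ccccc2)cc2c1c(N)nn2C`: -1%
compound 3, `Cc1cc2nc(-c3ccccc3)nc(N)c2c(=O)[nH]1`: 2%

All three numbers lie within the scatter of one another, so no order among compound 1, compound 2 and compound 3 is read from them. Among the compounds with values here, the one single-point step, a number 2 percentage points lower from compound 2 to compound 1 (within the scatter), goes with methyl in place of phenyl on an aromatic carbon.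

Compound 4, `Cc1nc(N)c2c(=O)[nH]c(C)cc2n1`, is not yet measured in this assay. It differs from compound 3 by methyl in place of phenyl on an aromatic carbon. How the core of compound 3 differs from that of compound 2 is not broken down here. The change from compound 3 to compound 4 is therefore the same kind of change as that from compound 2 to compound 1, not the same: in compound 2 the phenyl sits next to the ring nitrogen of a six-membered aromatic ring with one nitrogen, meta to a (2-methoxyethyl)amino group; in compound 3 it sits between two ring nitrogen atoms of a six-membered aromatic ring with two nitrogen, meta to an amino group.

A step of a number 2 percentage points lower from compound 3 to compound 4 (within the scatter) is expected in this assay, because the same kind of change gave a number 2 percentage points lower from compound 2 to compound 1 (within the scatter). Compound 4 is estimated at 0%, with the expected range running from -10% to 10%.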

Compound 4, a percentage reported as inhibition, at one concentration (the size of the read-out at that concentration, not a potency): 2%
Compound 4: middle estimate off by 2 percentage points, on the low side; measured number inside the range.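

In this assay methyl in place of phenyl on an aromatic carbon gives no change at the digits printed from compound 3 to compound 4 (within the scatter). Set beside the earlier step, the change reads alike on the two cores: the same change on two cores in this assay, a number 2 percentage points lower (within the scatter) from compound 2 to compound 1 and no change at the digits printed (within the scatter) from compound 3 to compound 4, 2 percentage points apart, within the scatter of two such steps. This shows that the change moved the read-out by no more than the scatter on either core, but not that it carries over in any wider sense, as the four numbers stand within the scatter and a step on a core with clear inhibition is not among those shown.

Open, on these data alone, is whether a primary amine, a carboxylic acid or a longer chain on that aromatic carbon would give a read-out distinct from these. Also open, as far as these compounds go, is how a group of that kind would behave on each of the two cores.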